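Trifluoromethyl for methoxy on a shared core

The source may hold more compounds than are shown below. What is called first, only, known or untested is meant among the compounds shown, and "the series" means these compounds.

In a functional assay on HeLa cells (Homo sapiens) for antiproliferative activity, read by MTT assay, with a stated time of 48 h (a lower number here means a stronger inhibitor, a higher number a weaker inhibitor), compound 1 `Clc1ccc(-c2nn(-c3ccccc3)cc2-c2nc3cc(Br)ccc3[nH]2)cc1` gives 2160 nM and compound 2 `COc1ccc2[nH]c(-c3cn(-c4ccccc4)nc3-c3ccc(Cl)cc3)nc2c1` gives 3630 nM. These two values lie within the usual scatter of each other, so compound 2 stands level with compound 1. Compound 3 `FC(F)(F)c1ccc2[nH]c(-c3cn(-c4ccccc4)nc3-c3ccc(Cl)cc3)nc2c1` has trifluoromethyl in place of methoxy on an aromatic carbon. Among the compounds with values here, one measured step bears on this carbon, methoxy in place of bromo, and it is small: a 1.7-fold higher number from compound 1 to compound 2 (0.23 log units; within the scatter). On that single step, no change beyond the scatter is expected in this assay. The expected step is a 1.3-fold lower number from compound 2 to compound 3 (0.11 log units; within the scatter). For compound 3 the estimated value is 2800 nM, with an expected range of 1100 nM to 7000 nM.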

Compound 3, half-maximal inhibitory concentration: 4420 nM
Compound 3: middle estimate off by 1.6-fold (0.20 log units), on the low side; low and high end bracket the measured number.
By their numbers in this assay, from the lowest: compounds 1, 2 and 3 (each within the scatter of the next, the first and the last beyond it).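

In this assay, this carbon has now carried three groups, and trifluoromethyl in place of methoxy gives a 1.2-fold higher number from compound 2 to compound 3 (0.09 log units; within the scatter), so the two groups stand level here. Trifluoromethyl in place of bromo gives a 2.0-fold higher number from compound 1 to compound 3 (0.31 log units; beyond the scatter), a modest step and the only one among these three compounds that passes the scatter. Nothing available here explains either step. Still open, going by these compounds, is whether an amine or a carboxylic acid on this same carbon would shift the number further than any of these groups does.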